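Compound 3 as the reference for a 4-chlorophenyl group

The source may report more compounds than this note shows. Statements on the series, on what has been measured and on what is new or still open speak of the compounds shown alone.

In an ADME assay on HeLa cells (Homo sapiens) for inhibition, read by MTT assay, with a stated time of 48 h (a lower number here means a stronger inhibitor, a higher number a weaker inhibitor), compound 1 `CCOC(=O)C(=O)CC(=O)/C=C/c1cn(-c2ccc(Cl)cc2)c2ccccc12` stands as "not determined" (no result reported), so it gives no number to work from. Compound 2 `CC(C)CCn1cc(/C=C/C(=O)CC(=O)C(=O)O)c2ccccc21` reads > 80000 nM, which is a limit of the assay and not a number. For the measured compounds named here, compound 3 `C=C(C)Cn1cc(/C=C/C(=O)CC(=O)C(=O)O)c2ccccc21` gives 40000 nM, the only actual number so far.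

The next compound is compound 4 `O=C(/C=C/c1cn(-c2ccc(Cl)cc2)c2ccccc12)CC(=O)C(=O)O`, which carries 4-chlorophenyl in place of 2-methylprop-2-en-1-yl on an aromatic nitrogen. Going by the values given here, the only measured step, an at least 2.0-fold lower number from compound 2 to compound 3 (0.30 log units; that floor lies within the scatter), has a floor within the scatter and involves no aromatic group. It therefore offers only weak guidance on size and none on direction for this change. Compound 1 also carries 4-chlorophenyl but has no result, so it adds nothing here.

No change beyond the scatter is expected in this assay, and the estimated step is a 1.3-fold lower number from compound 3 to compound 4 (0.12 log units; within the scatter). For compound 4 the expected value is 30000 nM, with an estimated range of 10000 nM to 80000 nM.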

Compound 4, half-maximal inhibitory concentration: > 40000 nM
Compound 4 ended at the assay's limit (the forecaster's own chance of this, stated with the estimate: 30%); at least 1.3-fold (0.12 log units) between middle value and limit.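

In this assay compound 4 gives > 40000 nM, a limit of the assay and not a number: the limit of > 40000 nM in this assay, at which 1 of the 4 values shown sits.

For the compounds shown here, putting 4-chlorophenyl in place of 2-methylprop-2-en-1-yl on the aromatic nitrogen gives a number no lower from compound 3 to compound 4 (the limit leaves the size open), the first reading at this position for an aromatic ring rather than an open chain. It shows a direction only: this ring gives no stronger inhibition here than the 2-methylprop-2-en-1-yl chain. The step from compound 2 to compound 4 joins two limits and cannot be read.

Going by these compounds, the size of the change remains open, as does the part played by the chlorine rather than the ring, a question for a plain phenyl or a benzyl group on the same nitrogen. On these data alone, the ethyl ester compound 1 stands at "not determined" (no result reported), so the exchange of the carboxylic acid for that ester with 4-chlorophenyl in place also remains open.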